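The source may hold more compounds than are shown below. What is called first, only, known or untested is meant among the compounds shown, and "the series" means these compounds.

In a physicochemical assay for solubility, using the shake flask method, in simulated intestinal fluid, measured as kinetic solubility, with a stated time of 2 h, at 25 degrees C, at pH 6.5 (a higher number here means a more soluble compound, a lower number a less soluble compound), compound 3 `Cc1nc(C(N)=O)c(N)c2c1C(=O)N(Cc1ccccc1)C2=O` gives < 5000 nM, which is a limit and not a number. Compound 1 `CCOC(=O)c1nc(C)c2c(c1N)C(=O)N(Cc1ccccc1)C2=O` gives < 5000 nM, also a limit. Compound 3 therefore stands at the limit of < 5000 nM in this assay, at which 2 of the 3 values shown sit. Compound 2 `Cc1nc(C(=O)OC2CC2)c(N)c2c1C(=O)N(Cc1ccccc1)C2=O` is the only one of the three with a number, 202000 nM.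

The next structural change leads to compound 4 `Cc1noc(-c2nc(C)c3c(c2N)C(=O)N(Cc2ccccc2)C3=O)n1`: 3-methyl-1,2,4-oxadiazol-5-yl in place of carbamoyl on an aromatic carbon. Here 3-methyl-1,2,4-oxadiazol-5-yl takes the place of carbamoyl on an aromatic carbon, next to the ring nitrogen and ortho to an amino group.

For the measured compounds named here, three measured steps bear on this change. The first is an at least 40-fold lower number from compound 2 to compound 3 (1.60 log units; beyond the scatter), with amino in place of cyclopropyloxy on a carbonyl carbon. The second is a step that the two limits leave unreadable from compound 1 to compound 3, with amino in place of ethoxy. The third is an at least 40-fold higher number from compound 1 to compound 2 (1.60 log units; beyond the scatter), with cyclopropyl in place of ethyl on an oxygen next to a carbonyl group. Going by the values given here, none of the measured compounds carries the incoming group, so these steps show how far the read-out can move but not which way it will go here. Both readable steps run through compound 2, with its value of 202000 nM, so only a modest rise is expected. Another limit would be no surprise. The expected step is an at least 1.2-fold higher number from compound 3 to compound 4 (0.07 log units; that floor lies within the scatter). For compound 4 the estimated value is 6000 nM, with an expected range from 2000 nM to 50000 nM.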

Compound 4, solubility: < 5000 nM
Compound 4 gave a limit, no number; the forecaster's own chance of this, stated with the estimate: 60%; at least 1.2-fold (0.07 log units) between middle value and limit.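

In this assay compound 4 gives < 5000 nM, which is a limit and not a number. At this aromatic carbon, then, the 3-methyl-1,2,4-oxadiazol-5-yl group joins carbamoyl and ethoxycarbonyl at the same floor, so a five-membered aromatic ring in this place does not lift the read-out to a number, and the steps among these three compounds cannot be read: the limit of < 5000 nM in this assay, at which 3 of the 4 values shown sit.

For the compounds shown here, the one step that can be read is an at least 40-fold lower number from compound 2 to compound 4 (1.60 log units; beyond the scatter), with 3-methyl-1,2,4-oxadiazol-5-yl in place of cyclopropyloxycarbonyl, which leaves cyclopropyloxycarbonyl as the only one of the four groups at this position that gives a number.

The compounds shown leave open where the three compounds at the limit truly stand, and so whether the new ring and carbamoyl differ at all. They also leave open whether a carboxylic acid or an aminomethyl group on this aromatic carbon would give a number, and whether a longer chain such as butyl in place of cyclopropyl would keep the read-out of the cyclopropyl ester.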